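The compounds below may be only part of what the source reports. "The series", "measured", "known", "first", "only" and "open" are said of these compounds alone.

In a functional assay on THP-1 cells (Homo sapiens) for inhibition, read by sulforhodamine B assay, with a stated time of 48 h, tested at 50 uM (a lower number here means less inhibition of growth, a higher number more inhibition of growth at the concentration tested), compound 1 `COc1cc(/C=C/C(=O)/C=C/c2cccs2)ccc1OCc1cn(CCOc2cc(=O)oc3ccccc23)nn1` reads 76% and compound 2 `COc1cc(/C=C/C(=O)/C=C/c2cc(OC)c(OC)c(OC)c2)ccc1OCc1cn(CCOc2cc(=O)oc3ccccc23)nn1` reads 99% while compound 3 `COc1ccc(/C=C/C(=O)/C=C/c2ccc(OCc3cn(CCOc4cc(=O)oc5ccccc45)nn3)c(OC)c2)cc1OC` reads 90% on the same scale. Compound 3 holds the second highest of the three numbers, with a number 9 percentage points lower from compound 2 to compound 3 (within the scatter) as the link to its nearest neighbour, and it lies clear of compound 1.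

Compound 4 `COc1cc(/C=C/C(=O)/C=C/c2ccco2)ccc1OCc1cn(CCOc2cc(=O)oc3ccccc23)nn1` brings furan-2-yl in place of 3,4-dimethoxyphenyl on a double-bonded chain carbon bound to a double-bonded chain carbon as its change: furan-2-yl in place of 3,4-dimethoxyphenyl on a double-bonded chain carbon bound to a double-bonded chain carbon. Going by the values given here, no furan-2-yl compound has been measured yet. The nearest evidence is a number 14 percentage points higher from compound 1 to compound 3 (beyond the scatter) together with a number 23 percentage points higher from compound 1 to compound 2 (beyond the scatter) as the second case, both leaving thiophen-2-yl. Treating furan-2-yl as close to thiophen-2-yl is an assumption, but with compound 1 at 76% as the anchor, a modest fall rather than no change is expected in this assay for this replacement. The expected move is a number 14 percentage points lower from compound 3 to compound 4 (beyond the scatter) as estimated here. Compound 4 is estimated at 76% with an expected range of 60% to 90% for this measurement.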

Compound 4, percent growth inhibition at one concentration: 78%
Beside the measured number, compound 4's estimate is 2 percentage points below it; the range from low to high includes it.
By their numbers in this assay, from the lowest: compounds 1 and 4 (each within the scatter of the next); then compounds 3 and 2 (each within the scatter of the next).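

In this assay, furan-2-yl and thiophen-2-yl on a double-bonded chain carbon bound to a double-bonded chain carbon read alike, with a number 2 percentage points higher from compound 1 to compound 4 (within the scatter) as their link. The larger aryl groups now stand clear of both five-membered rings, since the furan-2-yl replacement gives a number 12 percentage points lower from compound 3 to compound 4 (beyond the scatter) and a number 21 percentage points lower from compound 2 to compound 4 (beyond the scatter) in the same direction as the earlier thiophen-2-yl steps, and none of the four compounds goes against this. No measurement shown gives a reason for these differences.

Open, as far as these compounds go, is whether the higher readings follow the methoxy groups or the six-membered aromatic ring itself, as the two change together in these compounds. A plain phenyl would separate the two, and a phenyl carrying an amine or a carboxylic acid would show how far this position tolerates other substituents.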